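A Methylurea in Place of an Acetamide

The source may hold more compounds than are shown below. What is called first, only, known or untested is meant among the compounds shown, and "the series" means these compounds.

Of the compounds shown here, two built on a shared core have been measured. Compound 1 `COC(=O)Nc1ccc(-c2nc3c(c(=O)n(C)c(=O)n3C)n2-c2ccc(OC)cc2)cc1` gives 4200 nM in a functional assay on MCF7 cells (Homo sapiens) for antiproliferative activity, read by MTT assay, with a stated time of 48 h; a higher number here means a weaker inhibitor, a lower number a stronger inhibitor. Compound 2 `COc1ccc(-n2c(-c3ccc(NC(C)=O)cc3)nc3c2c(=O)n(C)c(=O)n3C)cc1F` gives 2800 nM in this assay; these two numbers lie within the usual scatter of each other, so neither compound can be ranked ahead of the other. Compound 3 `CNC(=O)Nc1ccc(-c2nc3c(c(=O)n(C)c(=O)n3C)n2-c2ccc(OC)c(F)c2)cc1` is not yet measured. It differs from compound 2 in one place: methylamino in place of methyl on a carbonyl carbon. Among the measured compounds shown here, no measured pair isolates this change, so the step from compound 2 to compound 3 is expected to be small, within the scatter, as a 1.1-fold lower number from compound 2 to compound 3 (0.05 log units; within the scatter). Compound 3 is therefore expected to give about 2500 nM, with a range from 1000 nM to 6500 nM.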

Compound 3, half-maximal inhibitory concentration: 11600 nM
The estimate for compound 3 lay 4.6-fold (0.67 log units) below the measured number, outside the stated range (above it).
By their numbers in this assay, from the lowest: compounds 2 and 1 (each within the scatter of the next); then compound 3.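

Putting methylamino in place of methyl on a carbonyl carbon, which turns 4-acetamidophenyl into 4-((methylcarbamoyl)amino)phenyl, is not a neutral swap in this assay: it gives a 4.1-fold higher number from compound 2 to compound 3 (0.62 log units; beyond the scatter), beyond the scatter. Among the compounds shown here, this position therefore responds to a change of this small size, something the earlier compounds could not show, as no measured pair isolated a change here.

Still open, on these data alone, is how ethylamino, with its longer chain, or a plain amino group on this carbonyl carbon would compare in this assay. No available measurement explains the higher number for compound 3.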